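Isobutyl for cyclopropyl on the ring nitrogen of compound 1

The source may report more compounds than this note shows. Statements on the series, on what has been measured and on what is new or still open speak of the compounds shown alone.

Measured so far:
compound 1, `O=C(O)c1cc(-c2cccc(COc3ccc4c(=O)n(C5CC5)sc4c3)c2)ccc1Cl`, 70.6%
compound 2, `O=C1c2ccc(OCc3cccc(-c4ccc(C(F)(F)F)cc4F)c3)cc2CN1C1CCCC1`, "not determined" (no result reported)
compound 3, `COc1ccc(-c2cccc(COc3ccc4c(c3)CN(C3CCCC3)C4=O)c2)cc1C(=O)O`, 78%

In an assay on HEK293 cells for positive allosteric modulation of metabotropic glutamate receptor 2 (Rattus norvegicus), read by thallium flux (a higher number here means a larger maximal response, a lower number a smaller maximal response), compound 1 gives 70.6%. Compound 3 gives 78% in this assay, and the gap between compound 1 and compound 3 lies within the usual scatter of repeated measurements, so the two numbers cannot be told apart. Compound 2 has "not determined" (no result reported) in this assay, so nothing can be said of it. For the measured compounds named here, no pair of measured compounds differs in one place only, so no single structural step has yet been measured.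

Compound 4, `CC(C)Cn1sc2cc(OCc3cccc(-c4ccc(Cl)c(C(=O)O)c4)c3)ccc2c1=O`, differs from compound 1 in one place: isobutyl in place of cyclopropyl on an aromatic nitrogen. Going by the values given here, there is no measured step to guide what this exchange does to the largest response. With compound 1 and compound 3 sitting so close together in this assay, the maximal response appears not to move much across the changes seen so far, and the step from compound 1 to compound 4 is expected to be small, in no clear direction, with an estimated size of a number 1.4 percentage points higher from compound 1 to compound 4 (within the scatter). Compound 4 is therefore expected to reach 72% in this assay, with a range from 56% to 90%.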

Compound 4, largest response reached (reported as percent of maximum), in percent of the reference or control that the assay uses: 76.2%
The estimate for compound 4 lay 4.2 percentage points below the measured number; the measured number falls inside the stated range.
By their numbers in this assay, from the lowest: compounds 1, 4 and 3 (each within the scatter of the next).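

Isobutyl in place of cyclopropyl on the aromatic nitrogen gives the first step measured at a single place in this assay, a number 5.6 percentage points higher from compound 1 to compound 4 (within the scatter), so the difference between the two compounds cannot be separated from the scatter of repeated measurements. At this position, the three-membered ring of cyclopropyl can thus be exchanged for isobutyl, which has no ring, without a measurable change in the largest response. No measurement presented here offers an explanation for this result.

This single pair leaves open how a longer chain, or a chain ending in an amine or a hydroxyl group, would behave on the same nitrogen. It also leaves open whether the isobutyl-for-cyclopropyl step would give a similar result on a compound whose other parts differ from those of compound 1.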